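Notes on the 2,4-dichlorobenzyl ether, compound 4

The source may hold more compounds than are shown below. What is called first, only, known or untested is meant among the compounds shown, and "the series" means these compounds.

Three compounds of this series have been run in a functional assay on MGC-803 cells (Homo sapiens) for inhibition, read by MTT assay, with a stated time of 48 h; a higher number here means a weaker inhibitor, a lower number a stronger inhibitor. Compound 1 `Cc1ccc(NC(=S)NC(=O)c2ccc(OCc3ccc(C(F)(F)F)cc3)cc2)cc1-c1nc2ccccc2[nH]1` gives 6500 nM, compound 2 `Cc1ccc(COc2ccc(C(=O)NC(=S)Nc3ccc(C)c(-c4nc5ccccc5[nH]4)c3)cc2)cc1` gives 4980 nM, and compound 3 `Cc1ccc(NC(=S)NC(=O)c2ccc(OCc3ccccc3Cl)cc2)cc1-c1nc2ccccc2[nH]1` gives 45000 nM, the highest number of the three; the steps of a 6.9-fold higher number from compound 1 to compound 3 (0.84 log units; beyond the scatter) and a 9.0-fold higher number from compound 2 to compound 3 (0.96 log units; beyond the scatter) both lie beyond the scatter, while a 1.3-fold lower number from compound 1 to compound 2 (0.12 log units; within the scatter) does not. Compound 4 `Cc1ccc(NC(=S)NC(=O)c2ccc(OCc3ccc(Cl)cc3Cl)cc2)cc1-c1nc2ccccc2[nH]1` differs from compound 3 by chloro in place of hydrogen on an aromatic carbon. Within the data shown here, no measured step changes hydrogen to chloro, but both steps into compound 3 replaced a phenyl carrying a group para to the chain with 2-chlorophenyl and raised the number; restoring a para group is expected to move the number back part of the way, so a modest step downward, a 3.0-fold lower number from compound 3 to compound 4 (0.48 log units; beyond the scatter), is expected. Compound 4 is expected to give 15000 nM, within 5000 nM to 45000 nM.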

Compound 4, half-maximal inhibitory concentration: 3450 nM
Compound 4: middle estimate off by 4.3-fold (0.64 log units), on the high side; measured number outside the range, below it.
By their numbers in this assay, from the lowest: compounds 4, 2 and 1 (each within the scatter of the next); then compound 3.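

In this assay, chloro on the aromatic carbon para to a large group, meta to the chloro group already present, is a large change (a 13-fold lower number from compound 3 to compound 4 (1.12 log units; beyond the scatter)). With this second chloro in place, the 2-chloro group no longer goes with a high number: both a 1.4-fold lower number from compound 2 to compound 4 (0.16 log units; within the scatter) and a 1.9-fold lower number from compound 1 to compound 4 (0.28 log units; within the scatter) stay within the scatter. No measurement shown bears on the cause of the large step.

Open, as far as these compounds go, is whether a 4-chlorobenzyl ether without the 2-chloro group would give a similar number. Also open, from the compounds shown here alone, is whether a methoxy group or an amine on this carbon would do the same.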